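The source may report more compounds than this note shows. Statements on the series, on what has been measured and on what is new or still open speak of the compounds shown alone.

In an ADME assay on CRL8155 cells (Homo sapiens) for cytotoxicity, read by resazurin assay, with a stated time of 72 h (on this read-out lower numbers stand for an effect already at smaller amounts and higher numbers for an effect only at larger amounts of compound), compound 1 `NCCCC(=O)Nc1nc2ccc(C(=O)c3ccccc3)cc2[nH]1` gives a result reported only as a limit, > 30000 nM. Compound 2 `CN1CCC(CCn2c(N)nc3ccc(C(=O)c4ccccc4)cc32)CC1` likewise returns only a limit in this assay, > 30000 nM. Compound 2 thus stands at the limit of > 30000 nM in this assay, at which 2 of the 2 values shown sit, so nothing in the numbers shown sets it apart from compound 1. Compound 3 `CN1CCC[C@H]1CCn1c(N)nc2ccc(C(=O)c3ccccc3)cc21` has not yet been measured; it differs from compound 2 in one place, namely (1-methylpyrrolidin-2-yl in place of 1-methylpiperidin-4-yl on a saturated chain carbon, two bonds along the chain from an aromatic nitrogen). Within the data shown here, no step between two measured compounds has been recorded in this assay, so any expectation for compound 3 rests on the two limits and on the structural change alone. With both measured results sitting at the limit, the expected step is a step that the limit leaves unreadable from compound 2 to compound 3, that is, none beyond the usual scatter, and compound 3 is expected to remain at the limit as well. The estimate for compound 3 in this assay is 40000 nM, with a range from 20000 nM to 100000 nM.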

Compound 3, half-maximal effective concentration: > 30000 nM
Compound 3: a limit, no number (the forecaster's own chance of this, stated with the estimate: 85%); the middle value is on the limit's open side.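

In this assay compound 3 also returns only a limit, so no step can be read from compound 2 to compound 3: the limit of > 30000 nM in this assay, at which 3 of the 3 values shown sit.

The compounds shown leave open whether any change on the shared core would give a numerical value in this assay.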